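This account rests on a few compounds, and the source may have more. Where it says the series, first, only, none or still open, it means among the compounds named here.

Working notes on the series. In a functional assay on P388 cells (Mus musculus) for inhibition (a higher number here means a weaker inhibitor, a lower number a stronger inhibitor), compound 1 (`Cc1cccc(/C=C2\CCc3ccccc3C2=O)c1`) gives 16300 nM. Compound 2 (`O=C1/C(=C/c2ccc(Cl)cc2)CCCc2ccccc21`) gives 9500 nM, and these two numbers lie within the scatter of each other. Compound 3 (`CN(C)c1ccc(/C=C2\CCCc3ccccc3C2=O)cc1`) carries dimethylamino in place of chloro on an aromatic carbon, para to a large group: dimethylamino in place of chloro on an aromatic carbon. For the measured compounds named here, no measured pair shows this change, so no shift beyond the scatter is expected in this assay, in either direction. The expected change is a 1.2-fold lower number from compound 2 to compound 3 (0.07 log units; within the scatter). For compound 3 the estimated value is 8000 nM, with an expected range of 2500 nM to 25000 nM.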

Compound 3, half-maximal inhibitory concentration: 1900 nM
Compound 3: middle estimate off by 4.2-fold (0.62 log units), on the high side; measured number below the stated range.
By their numbers in this assay, from the lowest: compound 3; then compounds 2 and 1 (each within the scatter of the next).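

At this aromatic carbon, para to a large group, the substituent clearly matters: dimethylamino in place of chloro gives a 5.0-fold lower number from compound 2 to compound 3 (0.70 log units; beyond the scatter) in this assay. For the compounds shown here, this is the only single-place step so far, and it lies beyond the scatter. Nothing at hand explains the shift.

Still open, on these data alone, is whether a primary amine, a methoxy group or a morpholine at this carbon would lower the number as well. Also open, as far as these compounds go, is whether the same change carries over to the core of compound 1.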